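The source may report more compounds than this note shows. Statements on the series, on what has been measured and on what is new or still open speak of the compounds shown alone.

Measured so far in a functional assay on MCF7 cells (Homo sapiens) for antiproliferative activity, read by MTT assay, with a stated time of 48 h; on this read-out lower numbers stand for stronger inhibition and higher numbers for weaker inhibition:

Compound 1 `COc1ccc(C(=O)c2ccc(OC)c3c2C=CC(C)(C)O3)c(NC(=O)CN)c1` gives 1250 nM.
Compound 2 `COc1ccc(C(=O)c2ccc3c(c2)C=CC(C)(C)O3)c(NC(=O)CN)c1` gives 680 nM.
Compound 3 `CNCC(=O)Nc1cc(OC)ccc1C(=O)c1ccc(OC)c2c1C=CC(C)(C)O2` gives 3040 nM.

Compound 3 is compound 1 with one change, (methyl in place of hydrogen on an amine nitrogen), and that single change brought a 2.4-fold higher number from compound 1 to compound 3 (0.39 log units; beyond the scatter). Compound 2 and compound 1 share the same side chain but have different cores; the difference between the two cores is not broken down here. Compound 4 `CNCC(=O)Nc1cc(OC)ccc1C(=O)c1ccc2c(c1)C=CC(C)(C)O2` has not yet been measured. It is compound 2 with the change (methyl in place of hydrogen on an amine nitrogen), made at the same place as the change from compound 1 to compound 3, so it is the same change on the other core. Among the compounds with values here, the step from compound 2 to compound 4 is expected to be a 2.4-fold higher number from compound 2 to compound 4 (0.37 log units; beyond the scatter), because a 2.4-fold higher number from compound 1 to compound 3 (0.39 log units; beyond the scatter) is the only measured example of this change. On that basis compound 4 is expected to give about 1600 nM, most likely between 900 nM and 3200 nM.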

Compound 4, half-maximal inhibitory concentration: 1210 nM
Compound 4: middle estimate off by 1.3-fold (0.12 log units), on the high side; the range from low to high includes it.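

In this assay, methyl in place of hydrogen on the amine nitrogen brought a 1.8-fold higher number from compound 2 to compound 4 (0.25 log units; within the scatter), so on this core the step alone cannot be told apart from the noise of repeated measurement. Set beside the step on the other core, the two steps cannot be told apart either: the same change on two cores in this assay, a 2.4-fold higher number (0.39 log units; beyond the scatter) from compound 1 to compound 3 and a 1.8-fold higher number (0.25 log units; within the scatter) from compound 2 to compound 4, 1.4-fold (0.14 log units) apart, within the scatter of two such steps. The change therefore carried across these two cores with no detectable difference in size, but this does not show that compound 4 truly differs from compound 2, nor that the same would hold on any further core.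

The compounds shown leave open what ethyl or a second methyl on that nitrogen would do. They also leave open how a longer chain in place of the aminomethyl would read out.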